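Swapping a methoxyphenyl for a dichlorophenyl on the shared core

The source may report more compounds than this note shows. Statements on the series, on what has been measured and on what is new or still open speak of the compounds shown alone.

Of the compounds shown here, three sharing one core have been measured in a functional assay on WM 266-4 cells (Homo sapiens) for antiproliferative activity, read by MTT assay, with a stated time of 48 h; on this read-out lower numbers stand for stronger inhibition of growth and higher numbers for weaker inhibition of growth. Compound 1 `S=C(Nc1ccccc1)N1N=C(c2ccccc2)CC1c1ccc2c(c1)OCCO2` gives 3180 nM. Compound 2 `O=[N+]([O-])c1ccc(C2=NN(C(=S)Nc3ccccc3)C(c3ccc4c(c3)OCCO4)C2)cc1` gives 105000 nM, and compound 3 `COc1cccc(C2=NN(C(=S)Nc3ccccc3)C(c3ccc4c(c3)OCCO4)C2)c1` gives 1380 nM, the lowest of the three numbers. The steps show a 33-fold higher number from compound 1 to compound 2 (1.52 log units; beyond the scatter), a 2.3-fold lower number from compound 1 to compound 3 (0.36 log units; beyond the scatter) and a 76-fold lower number from compound 2 to compound 3 (1.88 log units; beyond the scatter).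

Compound 4 `S=C(Nc1ccccc1)N1N=C(c2ccc(Cl)c(Cl)c2)CC1c1ccc2c(c1)OCCO2` differs from compound 3 in one place: 3,4-dichlorophenyl in place of 3-methoxyphenyl on a carbon with a double bond to nitrogen. Going by the values given here, no measured step exchanges these two groups directly. The two substituent changes recorded on this ring ran in opposite directions, one large and unfavourable, one modest and favourable, so a substituent on this ring can move the number a great deal or only a little. The most cautious reading places compound 4 near compound 1 and compound 3 rather than near compound 2. Compound 4 is therefore expected to give about 3000 nM in this assay, within 800 nM to 12000 nM. For compound 4 this expected change is a 2.2-fold higher number from compound 3 to compound 4 (0.34 log units; beyond the scatter).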

Compound 4, concentration for 50% growth inhibition: 58700 nM
Estimate against measurement, compound 4: 20-fold (1.29 log units) below, and the stated range ends below it.
By their numbers in this assay, from the lowest: compound 3; then compound 1; then compounds 4 and 2 (each within the scatter of the next).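

At this carbon with a double bond to nitrogen in this assay, 3,4-dichlorophenyl gives a much weaker result than either phenyl (an 18-fold higher number from compound 1 to compound 4 (1.27 log units; beyond the scatter)) or 3-methoxyphenyl (a 43-fold higher number from compound 3 to compound 4 (1.63 log units; beyond the scatter)). Set against 4-nitrophenyl, it gives a result level with that group (a 1.8-fold lower number from compound 2 to compound 4 (0.25 log units; within the scatter)), so a very high number here does not belong to the nitro compound alone. Of the three substituted rings, only 3-methoxyphenyl gives a lower number than plain phenyl, while 4-nitrophenyl and 3,4-dichlorophenyl go against that direction.

No measurement shown explains why these groups differ. The compounds shown leave open whether one chlorine would act like two, as in 3-chlorophenyl or 4-chlorophenyl, and how 4-methoxyphenyl or 4-aminophenyl would behave at this position.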